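Replacing the pyridine ring with an ethenyl amide chain

The source may hold more compounds than are shown below. What is called first, only, known or untested is meant among the compounds shown, and "the series" means these compounds.

Measured so far:
compound 1 `COc1ccc(-c2cncc(C(=O)N(C)C)c2)cc1S(=O)(=O)Nc1cccc(NCCNC(=O)c2cccc(C)c2)c1`: 7530 nM
compound 2 `COc1ccc(-c2ccnc(C(=O)N(C)C)c2)cc1S(=O)(=O)Nc1cccc(NCCNC(=O)c2cccc(C)c2)c1`: 5170 nM

In a functional assay on CHO-RD-HGA16 cells for agonist activity at Orexin/Hypocretin receptor type 1 (Homo sapiens), read by fluorescence and calcium flux, with a stated time of 30 min (on this read-out higher numbers stand for an effect only at larger amounts of compound and lower numbers for an effect already at smaller amounts), compound 1 gives 7530 nM; this is the highest of the two numbers measured, and compound 2 sits close to it, since the step of a 1.5-fold lower number from compound 1 to compound 2 (0.16 log units; within the scatter) is within the scatter. Compound 3 `COc1ccc(/C=C/C(=O)N(C)C)cc1S(=O)(=O)Nc1cccc(NCCNC(=O)c2cccc(C)c2)c1` has not yet been measured. It differs from compound 1 in one place: 2-(dimethylcarbamoyl)ethenyl in place of 5-(dimethylcarbamoyl)pyridin-3-yl on an aromatic carbon. Going by the values given here, the only measured step, from compound 1 to compound 2, moves the dimethylcarbamoyl group within the same ring and is within the scatter; it does not test removing the ring altogether, so nothing measured bears directly on this change. With no guide from the data, a step of modest size is expected, and the direction is uncertain; the estimate for compound 3 is therefore 10000 nM (range 3000 nM to 30000 nM), which would mean the step of a 1.3-fold higher number from compound 1 to compound 3 (0.12 log units; within the scatter).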

Compound 3, half-maximal effective concentration: > 10000 nM
Compound 3 gave a limit, no number (the forecaster's own chance of this, stated with the estimate: 25%); the middle value lies on the limit itself.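

In this assay compound 3 gives only a limit, not a number: the limit of > 10000 nM in this assay, at which 1 of the 3 values shown sits.

This is the first compound shown in which the pyridine ring is gone, leaving a 2-(dimethylcarbamoyl)ethenyl chain on the aromatic carbon para to the methoxy group, whereas the earlier step only moved the dimethylcarbamoyl group around that ring. The change gives an at least 1.3-fold higher number from compound 1 to compound 3 (0.12 log units; that floor lies within the scatter) and an at least 1.9-fold higher number from compound 2 to compound 3 (0.28 log units; that floor lies within the scatter), so swapping the ring for the open chain brings no sign of an effect at smaller amounts of compound, but no loss beyond the scatter is shown either.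

Going by these compounds, how far compound 3 really lies past its limit stays open, and with it whether losing the ring costs anything. Also open, on these data alone, is how a carboxylic acid in place of the dimethylcarbamoyl group on the ethenyl chain would read.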